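This account rests on a few compounds, and the source may have more. Where it says the series, first, only, none or still open, it means among the compounds named here.

Measured compounds, in a functional assay on MKN-45 cells (Homo sapiens) for cytotoxicity, read by MTT assay, with a stated time of 72 h; on this read-out lower numbers stand for stronger inhibition and higher numbers for weaker inhibition:

Compound 1 `CN(C)CCn1cnnc1-c1cc(Oc2ccc(NC(=O)N/N=C/c3ccc(Cl)cc3Cl)cc2F)ccn1` gives 750 nM.
Compound 2 `CN(C)CCn1cnnc1-c1cc(Oc2ccc(NC(=O)N/N=C/c3ccc(O)c(Br)c3)cc2F)ccn1` gives 1860 nM.
Compound 3 `COc1ccc(/C=N/NC(=O)Nc2ccc(Oc3ccnc(-c4nncn4CCN(C)C)c3)c(F)c2)c(OC)c1OC` gives 2020 nM.

Compound 1 has the lowest number of the three, and both of the other compounds sit beyond the usual scatter above it, so it is the strongest of the measured set in this assay. The unmeasured compound 4 `CN(C)CCn1cnnc1-c1cc(Oc2ccc(NC(=O)N/N=C/c3cccc(Br)c3)cc2F)ccn1` differs from compound 1 in one place: 3-bromophenyl in place of 2,4-dichlorophenyl on a carbon with a double bond to nitrogen. Two measured steps start from compound 1 and change the same group. The change to a bromine-bearing phenyl with a hydroxyl gave a 2.5-fold higher number from compound 1 to compound 2 (0.39 log units; beyond the scatter), and the change to a trimethoxyphenyl gave a 2.7-fold higher number from compound 1 to compound 3 (0.43 log units; beyond the scatter). Both replacements weakened cytotoxicity by a modest amount. The group entering compound 4 keeps a halogen on the ring, as in compound 1, so the step is expected to be smaller than those two, yet a slight weakening is expected, giving a 1.5-fold higher number from compound 1 to compound 4 (0.17 log units; within the scatter). Compound 4 is therefore estimated at 1100 nM, with a range from 500 nM to 2500 nM.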

Compound 4, half-maximal inhibitory concentration: 450 nM
Compound 4: middle estimate off by 2.4-fold (0.39 log units), on the high side, and the stated range ends above it.
By their numbers in this assay, from the lowest: compounds 4 and 1 (each within the scatter of the next); then compounds 2 and 3 (each within the scatter of the next).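

In this assay, a ring with a single bromine holds up as well as the ring with two chlorines: the step is a 1.7-fold lower number from compound 1 to compound 4 (0.22 log units; within the scatter), so this position accepts at least one replacement without a readable loss. Removing only the hydroxy group isolates that one change and gives a 4.1-fold lower number from compound 2 to compound 4 (0.62 log units; beyond the scatter), so the bromine-bearing ring does better here without it. The 3-bromophenyl group in place of 2,3,4-trimethoxyphenyl gives a similar step, a 4.5-fold lower number from compound 3 to compound 4 (0.65 log units; beyond the scatter), which places compounds 1 and 4 together, apart from compounds 2 and 3.

Going by these compounds, what a phenyl ring carrying an amine or a carboxylic acid in place of the bromine would do at this position remains open. Nothing shown here explains why these replacements differ.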